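Thioester in place of an amide at the furanyl dihydropyrimidinone

The compounds below may be only part of what the source reports. "The series", "measured", "known", "first", "only" and "open" are said of these compounds alone.

Measured compounds:
compound 1 `CC1=C(C(=O)C2CC2)C(c2ccco2)NC(=O)N1` — 7%
compound 2 `CCNC(=O)C1=C(C)NC(=O)NC1c1ccco1` — 3%
compound 3 `CC1=C(C(=O)NC(C)C)C(c2ccco2)NC(=O)N1` — 4%

In an assay on membranes from HeLa cells for displacement of a labelled ligand from adenosine receptor A3 (Homo sapiens), read by scintillation counting, with a stated time of 180 min, tested at 1 uM (a lower number here means less inhibition, a higher number more inhibition at the concentration tested (going by the name of the read-out)), compound 1 gives 7%, compound 2 gives 3% and compound 3 gives 4%. All three values lie within the usual scatter of one another, so compound 3 stands level with both neighbours. Compound 4 `CC1=C(C(=O)SC(C)C)C(c2ccco2)NC(=O)N1` differs from compound 3 in one place: isopropylsulfanyl in place of isopropylamino on a carbonyl carbon. Among the compounds with values here, no measured step makes this exact change; the nearest are a number 3 percentage points lower from compound 1 to compound 3 (within the scatter) and a number 4 percentage points lower from compound 1 to compound 2 (within the scatter), both on the same carbonyl carbon and both within the scatter. The expected step in this assay is therefore none beyond the scatter, a number 1 percentage points higher from compound 3 to compound 4 (within the scatter). Compound 4 is expected to give about 5%, estimated between -5% and 15%.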

Compound 4, a percentage reported as inhibition, at one concentration (the size of the read-out at that concentration, not a potency): 1%
Compound 4: middle estimate off by 4 percentage points, on the high side; the measured number falls inside the stated range.
By their numbers in this assay, from the lowest: compounds 4, 2, 3 and 1 (each within the scatter of the next).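

In this assay, isopropylsulfanyl on the carbonyl carbon, which has no hydrogen-bond donor where isopropylamino has one, gives no readable change (a number 3 percentage points lower from compound 3 to compound 4 (within the scatter)). The steps from the other two compounds also stay within the scatter (a number 2 percentage points lower from compound 2 to compound 4 (within the scatter); a number 6 percentage points lower from compound 1 to compound 4 (within the scatter)), so a sulfur link joins the nitrogen and carbon links at this position without separating from them. No evidence bears on this result.

The compounds shown leave open whether any group on this carbonyl carbon can move the number beyond the scatter. As far as these compounds go, a carboxylic acid or a longer chain there remains untested among them.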